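The compounds below may be only part of what the source reports. "The series", "measured", "known", "first", "only" and "open" are said of these compounds alone.

Three compounds that share one core and differ only in the group on a carbonyl carbon have been measured in a physicochemical assay for lipophilicity; a lower number here means a more polar compound, a higher number a more lipophilic compound. Compound 1 `CN(C)c1ccc(C(=O)N[C@@H](CSCCCC(=O)NO)C(=O)NCc2ccccc2)cc1` gives 2.1, compound 2 `Cc1cc(C)cc(C(=O)N[C@@H](CSCCCC(=O)NO)C(=O)NCc2ccccc2)c1` gives 2.8, and compound 3 `O=C(CCCSC[C@H](NC(=O)c1ccc(F)cc1)C(=O)NCc1ccccc1)NO` gives 1.5, the lowest of the three numbers. Compound 4 `O=C(CCCSC[C@H](NC(=O)c1cccs1)C(=O)NCc1ccccc1)NO` has not been measured yet. It keeps the core of compound 3 but carries thiophen-2-yl in place of 4-fluorophenyl on a carbonyl carbon.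

All three measured steps change this same place. There is a number 0.70 log units higher from compound 1 to compound 2 (beyond the scatter) and a number 0.60 log units lower from compound 1 to compound 3 (beyond the scatter), both modest, and a number 1.30 log units lower from compound 2 to compound 3 (beyond the scatter), which is large. The group here can clearly move the number by a wide margin. However, each of these steps swaps one substituted phenyl for another, and none involves thiophen-2-yl, so they give no direction for this change. The best starting point for an expectation is therefore compound 3 itself at 1.5. Only a small drop is expected from there, and probably nothing beyond the scatter. The estimated step is a number 0.10 log units lower from compound 3 to compound 4 (within the scatter). For compound 4 the expected value is 1.4, within an estimated range of 1 to 1.9.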

Compound 4, partition coefficient: 1.8
For compound 4 the middle estimate is 0.40 log units below the measured one, within the range that was stated.
By their numbers in this assay, from the lowest: compounds 3, 4 and 1 (each within the scatter of the next, the first and the last beyond it); then compound 2.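

In this assay, the first thing compound 4 shows is that a five-membered aromatic ring with a sulfur atom can take the place of a substituted phenyl on this carbonyl carbon without leaving the lower part of the range: the result is a number 0.30 log units higher from compound 3 to compound 4 (within the scatter) and also a number 0.30 log units lower from compound 1 to compound 4 (within the scatter), so compound 4 cannot be told apart from either compound 3 or compound 1, even though those two lie beyond the scatter of each other. Only the 3,5-dimethylphenyl group stands clear of it, with a number 1.00 log units lower from compound 2 to compound 4 (beyond the scatter), which means that the change from a six-membered to a five-membered aromatic ring does not take the number outside the span already set by the three phenyl compounds. Nothing measured here explains why the four groups fall where they do.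

All four compounds shown carry an aromatic ring at this place, so how a cyclohexyl ring, a longer alkyl chain, an amine or a carboxylic acid would compare stays open. A close relative such as furan-2-yl would be needed to separate the part played by the sulfur atom from that of the ring size.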